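This account rests on a few compounds, and the source may have more. Where it says the series, first, only, none or still open, it means among the compounds named here.

Among the compounds with values here, compound 1 `O=C1O[C@H]([C@@H](O)Cn2cc(-c3cccc(O)c3)nn2)C(OCc2ccccc2)=C1OCc1ccccc1` is the only member of this small set with a numerical result: in a functional assay on HCT-116 cells (Homo sapiens) for antiproliferative activity, read by MTT assay, with a stated time of 72 h (a higher number here means a weaker inhibitor, a lower number a stronger inhibitor), compound 1 gives 42900 nM. Compound 2 `CC(C)(C)OC(=O)N1CCN(C(=S)SCc2cn(C[C@H](O)[C@H]3OC(=O)C(OCc4ccccc4)=C3OCc3ccccc3)nn2)CC1`, built on the same core, reaches only the limit of this assay, where compound 2 gives > 100000 nM. Compound 1 therefore stands as the single measured point. The other entry sits at the limit of > 100000 nM in this assay, at which 1 of the 2 values shown sits. Compound 3 `O=C1O[C@H]([C@@H](O)Cn2cc(CCCCl)nn2)C(OCc2ccccc2)=C1OCc1ccccc1` has not yet been tested in this assay. It differs from compound 1 by 3-chloropropyl in place of 3-hydroxyphenyl on an aromatic carbon. Within the data shown here, no step between two measured compounds is available to guide the size of this change, and compound 2 shows only that a different group on the core can carry activity past the limit. Compound 3 is expected to remain weak, with a step of a 1.4-fold higher number from compound 1 to compound 3 (0.15 log units; within the scatter) that may not exceed the usual scatter. Compound 3 is estimated at 60000 nM, between 20000 nM and 200000 nM.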

Compound 3, half-maximal inhibitory concentration: 36100 nM
Estimate against measurement, compound 3: 1.7-fold (0.22 log units) above; measured number inside the range.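

In this assay, the first step readable at this position is a 1.2-fold lower number from compound 1 to compound 3 (0.07 log units; within the scatter), so the two compounds cannot be told apart. The 3-chloropropyl chain has no ring, no hydrogen-bond donor and no hydrogen-bond acceptor, so the six-membered aromatic ring and the donor and acceptor of 3-hydroxyphenyl are not required for activity at this level in these cells. Nothing measured here explains why two such different groups give such close numbers.

As far as these compounds go, whether an amine, a carboxylic acid or a longer chain on this aromatic carbon would move the number beyond the scatter remains open. Within the data shown here, compound 2 gives > 100000 nM, which is a limit and not a number, so no step to or from it can be read.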